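Swapping the Bromophenyl for a Chloronitrophenyl Ring

This account rests on a few compounds, and the source may have more. Where it says the series, first, only, none or still open, it means among the compounds named here.

Two compounds in this set share a spiro core carrying a nitrile, an amino group and a triazole linked through a methylene bridge to an aromatic ring that bears a halogen. Compound 1 `N#CC1=C(N)Oc2c(c3nc4ccccc4nc3c3ccccc23)C12C(=O)N(Cc1cnnn1-c1ccccc1Br)c1ccccc12` was tested in a functional assay on HCT-116 cells (Homo sapiens) for antiproliferative activity, read by MTT assay, with a stated time of 48 h (on this read-out lower numbers stand for stronger inhibition and higher numbers for weaker inhibition), and compound 1 gives only > 50000 nM, which is a limit of the assay rather than a measured number. Compound 2 `N#CC1=C(N)Oc2c(N)cc3nc4ccccc4nc3c2C12C(=O)N(Cc1cnnn1-c1cccc(Br)c1)c1ccccc12`, which carries an extra amino group on the shared core and a 3-bromophenyl group, gives 26100 nM in this assay. Within the data shown here, the other value shown, that of compound 1, is a limit (the limit of > 50000 nM in this assay, at which 1 of the 2 values shown sits), so compound 2 stands as the only compound here with a real number attached to it.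

Compound 3 `N#CC1=C(N)Oc2c(N)cc3nc4ccccc4nc3c2C12C(=O)N(Cc1cnnn1-c1ccc(Cl)cc1[N+](=O)[O-])c1ccccc12` has not yet been measured. It differs from compound 2 in one place: 4-chloro-2-nitrophenyl in place of 3-bromophenyl on an aromatic nitrogen. Among the measured compounds shown here, no step between two numbered compounds is available to show how such a change plays out in this assay, so the expected step from compound 2 to compound 3 is small, a 1.2-fold lower number from compound 2 to compound 3 (0.07 log units; within the scatter), and not clearly beyond the usual scatter in either direction. The estimate for compound 3 in this assay is therefore 22000 nM, with a range from 7000 nM to 50000 nM.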

Compound 3, half-maximal inhibitory concentration: 28700 nM
Compound 3: middle estimate off by 1.3-fold (0.12 log units), on the low side; the range from low to high includes it.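

Among these compounds, exchanging 3-bromophenyl for 4-chloro-2-nitrophenyl on the aromatic nitrogen of the five-membered ring gives a 1.1-fold higher number from compound 2 to compound 3 (0.04 log units; within the scatter) in this assay and so offers the first direct reading of a change at this position. The entering ring carries a chlorine and a nitro group where the leaving ring carries a bromine, and it brings more heavy atoms and hydrogen-bond acceptors, yet the read-out does not separate the two compounds. Nothing measured here explains why these two rings read alike.

Among the compounds shown here, only two substituted phenyl rings can be compared at this position on this core, so one step says little about how widely the result holds. From the compounds shown here alone, whether an unsubstituted phenyl, a phenyl ring bearing an amine or a carboxylic acid, or a ring carrying the chlorine or the nitro group alone would move the number beyond the usual scatter remains open.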